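Nitro to fluoro swap on the benzyl ring

The compounds below may be only part of what the source reports. "The series", "measured", "known", "first", "only" and "open" are said of these compounds alone.

Measured so far:
compound 1 `N=C(NCc1ccccc1)[C@@H]1CCC(=O)N1Cc1ccc([N+](=O)[O-])cc1` gives 24%
compound 2 `COc1ccc(CNC(=N)[C@@H]2CCC(=O)N2Cc2ccc([N+](=O)[O-])cc2)cc1` gives 25.4%

In a functional assay on SH-SY5Y cells (Homo sapiens) for cytotoxicity, read by MTT assay, with stated times of 8 h, 30 min and 12 h, tested at 0.5 uM (a higher number here means a stronger effect of the compound at the concentration tested, a lower number a weaker effect), compound 2 stands highest of two numbers, nearest compound 1, with a number 1.4 percentage points higher from compound 1 to compound 2 (within the scatter) lying within the scatter. Compound 3 `COc1ccc(CNC(=N)[C@@H]2CCC(=O)N2Cc2ccc(F)cc2)cc1` is not yet measured; it differs from compound 2 by fluoro in place of nitro on an aromatic carbon. Going by the values given here, no measured step touches this ring: the only step available, a number 1.4 percentage points higher from compound 1 to compound 2 (within the scatter), concerns the methoxy on the other ring and is within the scatter. Nothing therefore points to a step beyond the scatter, and the expected step of a number 2.4 percentage points lower from compound 2 to compound 3 (within the scatter) is set near zero. For compound 3 the estimate is 23%, with a range from 10% to 36%.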

Compound 3, a percentage reported as activity, at one concentration (the size of the read-out at that concentration, not a potency): 36.7%
Compound 3: the middle estimate sits 13.7 percentage points below what was measured, and the stated range ends below it.
By their numbers in this assay, from the lowest: compounds 1 and 2 (each within the scatter of the next); then compound 3.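

In this assay, going by these compounds alone, fluoro in place of nitro on this aromatic carbon gives a number 11.3 percentage points higher from compound 2 to compound 3 (beyond the scatter), the only step beyond the scatter. The read-out therefore responds to this group, whereas the methoxy change on the other ring gave a number 1.4 percentage points higher from compound 1 to compound 2 (within the scatter). No measurement on hand accounts for the step.

As far as these compounds go, whether the rise comes from adding fluoro or from removing nitro remains open, and an amine or chloro on this carbon would help separate the two. Whether the step holds without the methoxy is also unknown.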